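Replacing the Group on the Carbonyl of Compound 3

The source may report more compounds than this note shows. Statements on the series, on what has been measured and on what is new or still open speak of the compounds shown alone.

In a functional assay on MCF7 cells (Homo sapiens) for antiproliferative activity, read by MTT assay, with a stated time of 48 h (on this read-out higher numbers stand for weaker inhibition and lower numbers for stronger inhibition), compound 1 `CCn1c(C(=O)NCCN(C)C)ccc1C(CC)(CC)c1ccc(OCCC(O)(CC)CC)c(C)c1` gives 430 nM and compound 2 `CCN(CC)CCNC(=O)c1ccc(C(CC)(CC)c2ccc(OCCC(O)(CC)CC)c(C)c2)n1CC` gives 550 nM. Exchanging dimethylamino for diethylamino between them gives a 1.3-fold higher number from compound 1 to compound 2 (0.11 log units; within the scatter). Compound 3 `C#CCCOC(=O)c1ccc(C(CC)(CC)c2ccc(OCCC(O)(CC)CC)c(C)c2)n1CC` gives > 50000 nM, and this is a limit of the assay, not a number.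

Compound 4 `CCn1c(C(=O)Nc2ccc(OC(F)(F)F)cc2)ccc1C(CC)(CC)c1ccc(OCCC(O)(CC)CC)c(C)c1` carries (4-(trifluoromethoxy)phenyl)amino in place of (but-3-yn-1-yl)oxy on a carbonyl carbon. For the measured compounds named here, no measured step makes this exact exchange, but two large ones change the same carbonyl carbon, each putting (but-3-yn-1-yl)oxy in place of an amino group. Compound 4 brings an amino group back to that carbon, though without a dimethylamino or diethylamino end, so only part of an at least 110-fold higher number from compound 1 to compound 3 (2.06 log units; beyond the scatter) and of an at least 90-fold higher number from compound 2 to compound 3 (1.95 log units; beyond the scatter) is expected to be regained, toward stronger inhibition. The expected change in this assay is an at least 10-fold lower number from compound 3 to compound 4 (1.00 log units; beyond the scatter). For compound 4 the estimated value is 5000 nM, with an expected range of 600 nM to 40000 nM.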

Compound 4, half-maximal inhibitory concentration: > 50000 nM
Compound 4 ended at the assay's limit; the forecaster's own chance of this, stated with the estimate: 25%; middle value at least 10-fold (1.00 log units) from the limit.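

In this assay compound 4 gives > 50000 nM, which is a limit of the assay, not a number. Putting 4-(trifluoromethoxy)phenyl on the amide-type nitrogen gives an at least 90-fold higher number from compound 2 to compound 4 (1.95 log units; beyond the scatter) when it replaces 2-(diethylamino)ethyl and an at least 110-fold higher number from compound 1 to compound 4 (2.06 log units; beyond the scatter) when it replaces 2-(dimethylamino)ethyl. An amino group on this carbonyl carbon is therefore not enough on its own to give a value inside the assay's range: among the compounds shown, only those with a dialkylaminoethyl chain on that nitrogen do so.

As far as these compounds go, the step between compound 3 and compound 4 cannot be read, because both compounds sit at the same limit: the limit of > 50000 nM in this assay, at which 2 of the 4 values shown sit. It remains open whether a 3-(dimethylamino)propyl chain or a 2-hydroxyethyl group on that nitrogen would give a value inside that range.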